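Removing Two Bromines from a Cytotoxicity Series

This account rests on a few compounds, and the source may have more. Where it says the series, first, only, none or still open, it means among the compounds named here.

Of the compounds shown here, three sharing one core have been tested in an ADME assay on MT4 cells (Homo sapiens) for cytotoxicity, read by MTT assay, with a stated time of 4 days; on this read-out higher numbers stand for lower toxicity in this test and lower numbers for higher toxicity in this test. Compound 1 `N#Cc1ccc(Nc2nc(Oc3c(Br)cc(Br)cc3Br)c3ccccc3n2)cc1` gives 58000 nM, compound 2 `N#Cc1ccc(Nc2nc(Oc3c(Cl)cc(Cl)cc3Cl)c3ccccc3n2)cc1` gives 56000 nM, and compound 3 `Cc1cc(Br)cc(Br)c1Oc1nc(Nc2ccc(C#N)cc2)nc2ccccc12` gives 150000 nM. Compound 3 stands highest of the three, with its nearest neighbour, compound 1, at a distance beyond the scatter, and compound 2 slightly further.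

The step to compound 4 `Cc1ccc(Oc2nc(Nc3ccc(C#N)cc3)nc3ccccc23)cc1` alters only the ring on the oxygen: 4-methylphenyl in place of 2,4-dibromo-6-methylphenyl on an oxygen on an aromatic ring. Two earlier steps bear on this. The swap of a 1.0-fold lower number from compound 1 to compound 2 (0.02 log units; within the scatter) changed nothing of note, while the move from a 2.6-fold higher number from compound 1 to compound 3 (0.41 log units; beyond the scatter) gave a modest rise, that is, a modest loss of toxicity. Compound 4 goes further in the same direction, losing both remaining bromines, so a modest further rise in this assay seems the likeliest outcome, although with two of three prior steps being small, a result within the scatter of compound 3 is also plausible.

The number for compound 4 is expected to be about 220000 nM, between 80000 nM and 600000 nM, an estimated step of a 1.5-fold higher number from compound 3 to compound 4 (0.17 log units; within the scatter), with some chance the assay reports only a limit.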

Compound 4, half-maximal cytotoxic concentration: 87000 nM
For compound 4 the middle estimate is 2.5-fold (0.40 log units) above the measured one; the range from low to high includes it.
By their numbers in this assay, from the lowest: compounds 2, 1, 4 and 3 (each within the scatter of the next, the first and the last beyond it).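

With both bromines gone from the ring on the oxygen, this assay shows a 1.7-fold lower number from compound 3 to compound 4 (0.24 log units; within the scatter) and so gives no clear change at this position. Compound 4 carries no halogen on that ring, yet the comparisons with the fully halogenated rings show a 1.6-fold higher number from compound 2 to compound 4 (0.19 log units; within the scatter) and a 1.5-fold higher number from compound 1 to compound 4 (0.18 log units; within the scatter) so it cannot be told apart from compound 1 or compound 2 either. Compound 3 does stand clearly apart from compound 1 and compound 2, but the number of halogens on the ring does not give a simple trend across these four compounds, and no separate measurement is available here to explain the result.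

The compounds shown leave open whether an amine or a carboxylic acid on this ring, or a longer chain in place of the methyl, would move the number beyond the scatter. They also leave open how the same 4-methylphenyl group would behave on a version of the core in which the nitrile is replaced by another group.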